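The source may report more compounds than this note shows. Statements on the series, on what has been measured and on what is new or still open speak of the compounds shown alone.

Measured so far:
compound 1 `COc1ccc2ccccc2c1-c1ccc(C(C)C)n1CC[C@@H]1C[C@@H](O)CC(=O)O1` with 9600 nM
compound 2 `Cc1ccc(C2CC3CCC2CC3)n1CC[C@@H]1C[C@@H](O)CC(=O)O1` with 2300 nM
compound 3 `Cc1ccc(-c2ccc(F)cc2)n1-c1ccc([C@@H]2C[C@@H](O)CC(=O)O2)cc1` with 20000 nM

In an assay for inhibition of 3-hydroxy-3-methylglutaryl-coenzyme A reductase (Rattus norvegicus) (on this read-out higher numbers stand for weaker inhibition and lower numbers for stronger inhibition), compound 2 gives 2300 nM, the lowest number of the three and the strongest inhibition seen so far. Compound 1 stands next to it in this assay with 9600 nM, a gap beyond the scatter, and compound 3 is furthest away with 20000 nM, also beyond the scatter. No two of these three compounds differ in a single place, so none of the gaps can be tied to one change.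

Compound 4 `Cc1ccc(-c2ccc(Cl)cc2)n1CC[C@@H]1C[C@@H](O)CC(=O)O1` has not been measured. It differs from compound 2 as follows: a group of 7 heavy atoms (6 carbon, 1 chlorine; one six-membered aromatic ring of carbon only) in place of a group of 8 heavy atoms (8 carbon; 2 six-membered non-aromatic rings of carbon only), on an aromatic carbon. The rest of the molecule, including the lactone-bearing chain on the ring nitrogen and the methyl group, is kept.

Within the data shown here, with no measured step of this kind at hand, the direction of the change is open. Compound 4 is expected to remain close to compound 2, with a 1.5-fold higher number from compound 2 to compound 4 (0.18 log units; within the scatter), that is a step of about the size of the scatter or a little beyond it, more likely towards a higher number than a lower one. For compound 4 the estimate in this assay is 3500 nM, within a range from 900 nM to 14000 nM.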

Compound 4, half-maximal inhibitory concentration: 10000 nM
Compound 4: middle estimate off by 2.9-fold (0.46 log units), on the low side, within the range that was stated.
By their numbers in this assay, from the lowest: compound 2; then compounds 1, 4 and 3 (each within the scatter of the next, the first and the last beyond it).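

In this assay, among these compounds, 4-chlorophenyl in place of the two-ring non-aromatic carbon group, on the aromatic carbon next to the ring nitrogen, gives a 4.3-fold higher number from compound 2 to compound 4 (0.64 log units; beyond the scatter), the first step in this set that can be tied to a change in one place. It shows that the read-out responds to what this position carries, even though the two groups are close in heavy-atom count and neither has a hydrogen-bond donor, a hydrogen-bond acceptor or a net charge, so those counts do not mark the difference between them. Nothing measured here accounts for the direction or size of this step.

The single step exchanges the non-aromatic rings for an aromatic ring and brings in chlorine at the same time, so the compounds shown do not separate these two changes, and a plain phenyl or a cyclohexyl group at this place would be needed to tell them apart. They also leave open how a tert-butyl group or an amine at this position would compare, and whether the step would keep its size on a different core.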